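Swapping Bromo for Methoxy on the Sulfonyl Analogue

The compounds below may be only part of what the source reports. "The series", "measured", "known", "first", "only" and "open" are said of these compounds alone.

Of the compounds shown here, three have been measured in a functional assay on A549 cells (Homo sapiens) for antiproliferative activity, read by MTT assay, with a stated time of 72 h; a lower number here means a stronger inhibitor, a higher number a weaker inhibitor.

Compound 1, `CN(C(=O)c1ccc(Br)cc1)c1ccc2[nH]c(-c3n[nH]c4ccccc34)cc2n1`: 4250 nM
Compound 2, `COc1ccc(C(=O)N(C)c2ccc3[nH]c(-c4n[nH]c5ccccc45)cc3n2)cc1`: 14600 nM
Compound 3, `CN(c1ccc2[nH]c(-c3n[nH]c4ccccc34)cc2n1)S(=O)(=O)c1ccc(Br)cc1`: 19700 nM

Compounds 1 and 2 differ only by methoxy in place of bromo on an aromatic carbon, and that change made a 3.4-fold higher number from compound 1 to compound 2 (0.54 log units; beyond the scatter). Compound 3 carries a different core; it differs from compound 1 by (4-bromophenyl)sulfonyl in place of (4-bromophenyl)carbonyl on a nitrogen on an aromatic ring, which brought a 4.6-fold higher number from compound 1 to compound 3 (0.67 log units; beyond the scatter). Between compound 2 and compound 3 the gap is a 1.3-fold higher number from compound 2 to compound 3 (0.13 log units; within the scatter).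

Compound 4, `COc1ccc(S(=O)(=O)N(C)c2ccc3[nH]c(-c4n[nH]c5ccccc45)cc3n2)cc1`, has not been measured. It arises from compound 3 by methoxy in place of bromo on an aromatic carbon, the same change as from compound 1 to compound 2, at a place described in the same words. The earlier step read a 3.4-fold higher number from compound 1 to compound 2 (0.54 log units; beyond the scatter), and a step of similar size is expected here, with some allowance for the change now sitting on a different core. Compound 4 is therefore expected to move by a 2.8-fold higher number from compound 3 to compound 4 (0.45 log units; beyond the scatter) in this assay. This rests on a single prior example, so the range is kept wide. Compound 4 is estimated at 55000 nM, with a likely range from 20000 nM to 150000 nM.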

Compound 4, half-maximal inhibitory concentration: 24300 nM
Estimate against measurement, compound 4: 2.3-fold (0.35 log units) above; measured number inside the range.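

In this assay, methoxy in place of bromo on the sulfonyl compounds gave a 1.2-fold higher number from compound 3 to compound 4 (0.09 log units; within the scatter), so on this core the swap makes no readable difference. Set beside the carbonyl pair, the same change did not carry over at the same size from one core to the other: the same change on two cores in this assay, a 3.4-fold higher number (0.54 log units; beyond the scatter) from compound 1 to compound 2 and a 1.2-fold higher number (0.09 log units; within the scatter) from compound 3 to compound 4, 2.8-fold (0.44 log units) apart, beyond the scatter of two such steps. Among the compounds shown here, this shows that the step read on the core of compound 1 was a poor guide to the step on the core of compound 3, but with only one pair on each core it does not show why the two steps differ, or whether other swaps at this spot would also differ between the cores.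

The compounds shown hold only bromo and methoxy at this spot, so what a chlorine, a nitrile or an amine there would do remains open on both cores. Also open, from the compounds shown here alone, is whether a longer chain such as ethyl, in place of the methyl on the nitrogen, would alter the gap between the two steps.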